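Compound 3 to compound 4: piperidin-1-yl for the arylamino group

A few compounds are considered here, and "the series" means these few. Any claim that something is new, unique, unknown or untested is made for them only; others in the source may bear on it.

Measured in a functional assay on ECa-109 cells for inhibition, with ECa-109 cell line (Homo sapiens) as the target, read by sulforhodamine B assay (a higher number here means a weaker inhibitor, a lower number a stronger inhibitor), as follows
- compound 1 `O=C1C(Nc2ccc(I)cc2)=CC(=O)c2c1nc1n2[C@H]2OC[C@@H](O)[C@H]2OC1` gives 2530 nM
- compound 2 `O=C1C(NC2CCCC2)=CC(=O)c2c1nc1n2[C@H]2OC[C@@H](O)[C@H]2OC1` gives > 16000 nM as a limit
- compound 3 `COc1ccccc1NC1=CC(=O)c2c(nc3n2[C@H]2OC[C@@H](O)[C@H]2OC3)C1=O` gives > 4000 nM as a limit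

Compound 3 stands only at a limit, so no number is available as a starting point. Compound 4 `O=C1C(N2CCCCC2)=CC(=O)c2c1nc1n2[C@H]2OC[C@@H](O)[C@H]2OC1` follows by the change piperidin-1-yl in place of (2-methoxyphenyl)amino on a double-bonded ring carbon with piperidin-1-yl in place of (2-methoxyphenyl)amino on a double-bonded ring carbon. Cyclopentyl in place of 4-iodophenyl gave an at least 6.3-fold higher number from compound 1 to compound 2 (0.80 log units; beyond the scatter) beyond the scatter. The step of an at least 1.5-fold higher number from compound 1 to compound 3 (0.19 log units; that floor lies within the scatter) has a floor within the scatter, and a step that the two limits leave unreadable from compound 2 to compound 3 cannot be read. Compound 2 carries a non-aromatic ring as compound 4 does. Compound 2 gives > 16000 nM, which is a limit. A modest move to a higher number is therefore expected in this assay and may again end in a limit. The expected step is a step that the limit leaves unreadable from compound 3 to compound 4 on this estimate. For compound 4 the estimated value is 12000 nM with an expected range of 4000 nM to 40000 nM in this assay.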

Compound 4, half-maximal inhibitory concentration: > 8000 nM
Compound 4: only a limit was reported; the forecaster's own chance of this, stated with the estimate: 55%; the middle value does not contradict the limit.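

In this assay compound 4 gives > 8000 nM, which is a limit. Piperidin-1-yl, which carries no hydrogen-bond donor, in place of (4-iodophenyl)amino gives an at least 3.1-fold higher number from compound 1 to compound 4 (0.49 log units; beyond the scatter), so a non-aromatic ring lacking that donor also stays weaker than compound 1 at this double-bonded ring carbon. The steps from compound 2 and from compound 3 to compound 4 cannot be read. Going by these compounds, whether the amine hydrogen matters therefore stays open. Also open, on these data alone, is how morpholin-4-yl or (4-chlorophenyl)amino would stand at this carbon.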